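The compounds below may be only part of what the source reports. "The series", "measured", "known", "first", "only" and "open" are said of these compounds alone.

Measured so far in an assay on isolated protein for inhibition of Indoleamine 2,3-dioxygenase 1 (Homo sapiens), with a stated time of 60 min, tested at 10 uM; a higher number here means more inhibition at the concentration tested (going by the name of the read-out), a lower number less inhibition:
compound 1, `c1ccc(CCc2ccccc2CSC2=NCCN2)cc1`: 17%
compound 2, `Clc1ccc2[nH]c(SCc3ccccc3CCCc3ccccc3)nc2c1`: 19%

Compound 2 gives 19% in this assay, and compound 1 gives 17%; the two numbers lie within the usual scatter of each other, so neither compound can be set above the other on this pair. Both sit in the low range of inhibition at the concentration tested.

Compound 3, `Clc1ccc2[nH]c(SCc3ccccc3/C=C/c3ccccc3)nc2c1`, is the next compound and has not yet been measured. It differs from compound 2 in one place: 2-phenylethenyl in place of 3-phenylpropyl on an aromatic carbon. Among the measured compounds shown here, no pair of measured compounds shows what this exchange does, so the expected step rests on the change alone and on the level of compound 2. The step from compound 2 to compound 3 in this assay is expected to be no change at the digits printed from compound 2 to compound 3 (within the scatter), which is none beyond the scatter. Compound 3 is accordingly estimated to give 19% in this assay, within the range from 6% to 36%.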

Compound 3, a percentage reported as inhibition, at one concentration (the size of the read-out at that concentration, not a potency): -6%
Compound 3: the middle estimate sits 25 percentage points above what was measured; measured number below the stated range.
By their numbers in this assay, from the lowest: compound 3; then compounds 1 and 2 (each within the scatter of the next).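

At this position, on an aromatic carbon ortho to a large group, the side chain is not a neutral place for exchange in this assay: 2-phenylethenyl in place of 3-phenylpropyl gives a number 25 percentage points lower from compound 2 to compound 3 (beyond the scatter) on the shared core. The exchange both removes one carbon from the group and brings in a double bond outside aromatic rings, so this single step cannot assign the drop to either change. Nothing measured here accounts for the step.

Open, as far as these compounds go, is how 2-phenylethyl would read on the core of compound 2, a comparison that would separate the length of the chain from the double bond. Also open, from the compounds shown here alone, is whether an amine or a carboxylic acid at this position would lift the inhibition above the level of compound 2.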